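Two Thiophene Carboxamides and an Untested Pyrazolylmethyl Analogue

The source may hold more compounds than are shown below. What is called first, only, known or untested is meant among the compounds shown, and "the series" means these compounds.

Compound 1 `Cc1ccc(C(=O)Nc2sc3c(c2C(N)=O)CCCC3)s1` gives 652 nM in an assay on cells for positive allosteric modulation of Cystic fibrosis transmembrane conductance regulator variant F508del (Homo sapiens), with stated times of 10 min and 7 s, in the presence of a further agent that is not named here; on this read-out lower numbers stand for an effect already at smaller amounts and higher numbers for an effect only at larger amounts of compound.
Compound 2 `CC1(C)Cc2c(sc(NC(=O)c3nnc[nH]3)c2C(N)=O)C(C)(C)O1` gives 467 nM in this assay.

The two measured compounds share a thiophene carboxamide bearing an acylated amine. In this assay compound 2 gives 467 nM, and the number for compound 1 lies within the usual scatter of it, so the two cannot be told apart on this read-out.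

Compound 3 `CC1(C)Cc2c(sc(NC(=O)Cc3ccn[nH]3)c2C(N)=O)C(C)(C)O1` has not been measured. It differs from compound 2 in one place: (1H-pyrazol-5-yl)methyl in place of 4H-1,2,4-triazol-3-yl on a carbonyl carbon. Among the measured compounds shown here, no measured pair shows the effect of such a change here, so any expectation rests on compound 2 alone. Since the ring that enters carries one acceptor fewer and is set off from the carbonyl by a methylene, the step of a 1.6-fold higher number from compound 2 to compound 3 (0.21 log units; within the scatter) is expected to be modest, most likely toward a somewhat higher number, and it may not exceed the scatter. For compound 3 the estimate in this assay is 750 nM, with a range from 250 nM to 2200 nM.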

Compound 3, half-maximal effective concentration: 136 nM
The estimate for compound 3 lay 5.5-fold (0.74 log units) above the measured number; the whole stated range lies above it.
By their numbers in this assay, from the lowest: compound 3; then compounds 2 and 1 (each within the scatter of the next).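

With (1H-pyrazol-5-yl)methyl in place of 4H-1,2,4-triazol-3-yl on a carbonyl carbon, the dimethylated core gives a 3.4-fold lower number from compound 2 to compound 3 (0.54 log units; beyond the scatter) in this assay. Among the compounds shown here, this is the first step measured at this position, and it shows that the read-out responds beyond the scatter to what sits on this carbonyl carbon, even though the group that enters and the group that leaves each hold one five-membered aromatic ring and no net charge. Nothing on hand accounts for the lower number with this change.

The step joins two changes, the ring itself and the methylene that sets it off from the carbonyl, and a 4H-1,2,4-triazol-3-ylmethyl group would be needed to tell them apart. Going by these compounds, how an aliphatic amine, a carboxylic acid or a longer chain would read on this carbonyl carbon also stays open.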